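The source may report more compounds than this note shows. Statements on the series, on what has been measured and on what is new or still open speak of the compounds shown alone.

Notes on the series. In a functional assay on HT-1080 cells (Homo sapiens) for antiproliferative activity, read by sulforhodamine B assay, with a stated time of 48 h (a higher number here means a weaker inhibitor, a lower number a stronger inhibitor), compound 3 `CCC(=O)Nc1ccc(S(=O)(=O)Oc2ccccc2I)cc1` gives 7200 nM, the second highest of the three numbers measured. Compound 1 `CC(=O)Nc1ccc(S(=O)(=O)Oc2ccccc2I)cc1` gives 17000 nM; compound 2 `CCC(=O)Nc1ccc(S(=O)(=O)Oc2ccccc2C(C)C)cc1` gives 2100 nM. The step of a 2.4-fold lower number from compound 1 to compound 3 (0.37 log units; beyond the scatter) bears directly on the change now considered, since it also extends the chain bound to the carbonyl; the step of a 3.4-fold higher number from compound 2 to compound 3 (0.54 log units; beyond the scatter) concerns the aromatic substituent and does not. Compound 4 `CCCC(=O)Nc1ccc(S(=O)(=O)Oc2ccccc2I)cc1` differs from compound 3 by methyl in place of hydrogen on a saturated chain carbon, two bonds along the chain from a carbonyl carbon. One further methyl on that chain is expected to give a modest lowering again, or none beyond the scatter, as compound 1 and compound 3 alone support the trend. The estimate for compound 4 is 4500 nM, range 1500 nM to 12000 nM, a step of a 1.6-fold lower number from compound 3 to compound 4 (0.20 log units; within the scatter) expected.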

Compound 4, half-maximal inhibitory concentration: 2000 nM
Beside the measured number, compound 4's estimate is 2.3-fold (0.35 log units) above it; the measured number falls inside the stated range.
By their numbers in this assay, from the lowest: compounds 4 and 2 (each within the scatter of the next); then compound 3; then compound 1.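

In this assay the chain bound to the carbonyl gives a further lowering, a 3.6-fold lower number from compound 3 to compound 4 (0.56 log units; beyond the scatter) and so extends the direction of a 2.4-fold lower number from compound 1 to compound 3 (0.37 log units; beyond the scatter) by one more methyl. Taken whole, the extension amounts to an 8.5-fold lower number from compound 1 to compound 4 (0.93 log units; beyond the scatter) and none of compound 1, compound 3 or compound 4 goes against the trend, which has been read only with iodo on the aromatic ring. Going by these compounds, whether a longer chain continues the lowering or reverses it stays open, as does the effect of an amine or a carboxylic acid at the chain end. Nothing available explains the lowering.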